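A few compounds are considered here, and "the series" means these few. Any claim that something is new, unique, unknown or untested is made for them only; others in the source may bear on it.

Measured so far in a functional assay on MIA PaCa-2 cells (Homo sapiens) for inhibition, read by MTT assay, with a stated time of 72 h; on this read-out higher numbers stand for weaker inhibition of growth and lower numbers for stronger inhibition of growth:
- compound 1 `O=S(=O)(NCCCCNCc1ccc(Br)cc1)c1cc(C(F)(F)F)cc(C(F)(F)F)c1` gives 2100 nM
- compound 2 `O=[N+]([O-])c1ccc(S(=O)(=O)NCCCCCCNCc2ccc(Br)cc2)cc1` gives 9800 nM
- compound 3 `O=S(=O)(NCCCCCCNCc1ccc(Br)cc1)c1cccc(C(F)(F)F)c1` gives 5970 nM

Compound 1 holds the lowest number of the three in this assay. Its nearest neighbour is compound 3, whose number stands higher by a margin beyond the usual scatter, and compound 2 sits further out again, also beyond the scatter. No pair of these compounds differs in a single place, so no single change can be read off from them.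

Compound 4 `O=S(=O)(NCCCNCc1ccccc1)c1cc(C(F)(F)F)cc(C(F)(F)F)c1` is not yet measured. Relative to compound 1 the change is benzylamino in place of ((4-bromobenzyl)amino)methyl on a saturated chain carbon, three bonds along the chain from a sulfonamide nitrogen. Going by the values given here, the shorter chain and the loss of the bromine on the aryl ring have no direct precedent here; the only hint is that compound 1, with the shortest chain of the three, also carries the lowest number, though compounds 2 and 3 differ from it in the sulfonyl aryl group as well.

A modest step toward a higher number in this assay is expected, close to the edge of the scatter. For compound 4 the estimate is 4000 nM, with a range of 1500 nM to 11000 nM. The expected step is a 1.9-fold higher number from compound 1 to compound 4 (0.28 log units; within the scatter).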

Compound 4, concentration for 50% growth inhibition: 11000 nM
Compound 4: the middle estimate sits 2.8-fold (0.44 log units) below what was measured; the range from low to high includes it.
By their numbers in this assay, from the lowest: compound 1; then compounds 3, 2 and 4 (each within the scatter of the next).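

Benzylamino in place of ((4-bromobenzyl)amino)methyl on a saturated chain carbon, three bonds along the chain from a sulfonamide nitrogen, gives in this assay the series' first readable single-place step, which is a 5.2-fold higher number from compound 1 to compound 4 (0.72 log units; beyond the scatter) and lies beyond the scatter. This position therefore responds to change while the sulfonyl aryl group stays the same. The step combines a shorter chain with loss of the bromine, so its size cannot be divided between those two differences, and no measurement available here gives a reason for it.

Still open, going by these compounds, is whether benzylamino on the longer chain of compound 1 would return toward the number of compound 1, or whether the bromine alone carries the difference. Chlorine or methoxy in place of the bromine, or a hexyl chain with the same sulfonyl aryl group, would separate these contributions.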